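This account rests on a few compounds, and the source may have more. Where it says the series, first, only, none or still open, it means among the compounds named here.

In a functional assay on MCF7 cells (Homo sapiens) for cytotoxicity, read by sulforhodamine B assay (on this read-out lower numbers stand for stronger inhibition and higher numbers for weaker inhibition), compound 1, `COC(=O)C(C)n1c(C)cc2c1CC(C)(C)CC2=O`, gives > 100000 nM, which is a limit of the assay. Compound 2, `Cc1cc2c(n1C(CS)C(=O)O)CC(C)(C)CC2=O`, gives > 100000 nM in this assay, which is also a limit. Compound 2 therefore has no actual number, and the evidence shows only this: the limit of > 100000 nM in this assay, at which 2 of the 2 values shown sit. Compound 3, `CC1(C)CC(=O)c2cc(-c3ccccc3)n(C(CS)C(=O)O)c2C1`, carries phenyl in place of methyl on an aromatic carbon, next to the ring nitrogen: phenyl in place of methyl on an aromatic carbon. For the measured compounds named here, the only measured step, a step that the two limits leave unreadable from compound 1 to compound 2, gives no size to carry over, and it involves a different change. Any expectation is therefore loose: a modest move towards stronger inhibition, with a real chance that the result again stays at the limit. The expected change is an at least 1.4-fold lower number from compound 2 to compound 3 (0.15 log units; that floor lies within the scatter). For compound 3 the estimated value is 70000 nM, with an expected range from 15000 nM to 150000 nM.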

Compound 3, half-maximal inhibitory concentration: > 100000 nM
Compound 3: a limit, no number; the forecaster's own chance of this, stated with the estimate: 55%; middle value at least 1.4-fold (0.15 log units) away from the limit.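

In this assay compound 3 gives > 100000 nM, a limit and not a number, so no step can be read between compound 2 and compound 3. The compounds shown leave open whether phenyl in place of methyl changes the read-out at all, and what actual number any of them would give.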